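Swapping a pyrazole for a pyridine on the anilino arm

This account rests on a few compounds, and the source may have more. Where it says the series, first, only, none or still open, it means among the compounds named here.

Measured in an assay on isolated protein for inhibition of Apoptosis regulator Bcl-2 (Homo sapiens), read by fluorescence polarization; a lower number here means a stronger inhibitor, a higher number a weaker inhibitor:
compound 1, `Cc1cc(Oc2ccc(Cn3nc4ccc(Cl)cc4c3C(=O)NS(=O)(=O)c3ccc(Cl)cc3)cc2)cc(C)c1Cl`, gives 510 nM
compound 2, `Cc1cc(Oc2ccc(Cn3nc4ccc(Cl)cc4c3C(=O)NS(=O)(=O)c3ccc(NCc4ccco4)c([N+](=O)[O-])c3)cc2)cc(C)c1Cl`, gives 570 nM
compound 3, `Cc1cc(Oc2ccc(Cn3nc4ccc(Cl)cc4c3C(=O)NS(=O)(=O)c3ccc(NCc4ccn(C)n4)c([N+](=O)[O-])c3)cc2)cc(C)c1Cl`, gives 600 nM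

Compound 3 cannot be set apart from the other two on these numbers: the step of a 1.1-fold higher number from compound 2 to compound 3 (0.02 log units; within the scatter) is within the scatter, and the numbers of compound 3 and compound 1 also sit within the scatter of each other, so all three read as equivalent in this assay.

Compound 4, `Cc1cc(Oc2ccc(Cn3nc4ccc(Cl)cc4c3C(=O)NS(=O)(=O)c3ccc(NCc4ccncc4)c([N+](=O)[O-])c3)cc2)cc(C)c1Cl`, differs from compound 3 by pyridin-4-yl in place of 1-methyl-1H-pyrazol-3-yl on a saturated chain carbon bound to a nitrogen on an aromatic ring. Within the data shown here, the one measured step that bears on this place is a 1.1-fold higher number from compound 2 to compound 3 (0.02 log units; within the scatter), where one small aromatic ring replaced another on the same saturated chain carbon and the number did not move beyond the scatter. Beyond that, compound 1 and compound 2 give numbers that also lie within the scatter of each other, so nothing measured here has shifted this assay. The step of a 1.0-fold higher number from compound 3 to compound 4 (0.01 log units; within the scatter) is therefore expected to be none beyond the scatter. Compound 4 is estimated at 620 nM, with a range from 280 nM to 1400 nM.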

Compound 4, inhibition constant: 1520 nM
For compound 4 the middle estimate is 2.5-fold (0.39 log units) below the measured one; measured number outside the range, above it.
By their numbers in this assay, from the lowest: compounds 1, 2 and 3 (each within the scatter of the next); then compound 4.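

This position is not indifferent to the ring it carries. In this assay, among these compounds, the pyridin-4-yl ring of compound 4 gives a 2.5-fold higher number from compound 3 to compound 4 (0.40 log units; beyond the scatter) and a 2.7-fold higher number from compound 2 to compound 4 (0.43 log units; beyond the scatter), the first steps at this place to go beyond the scatter, though both are modest. Nothing available explains why this ring differs from the other two.

The change from 1-methyl-1H-pyrazol-3-yl to pyridin-4-yl alters both ring size and the count of ring nitrogens at once, so these compounds cannot show which of the two matters. A plain phenyl ring on the same saturated chain carbon would help separate them, and pyridin-3-yl would show whether the place of the ring nitrogen counts.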